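Replacing the anilino with a methoxypiperidine on the shared core

A few compounds are considered here, and "the series" means these few. Any claim that something is new, unique, unknown or untested is made for them only; others in the source may bear on it.

Three measured compounds share one core and differ only in the group on one aromatic carbon. In a functional assay on CHO-K1 cells for antagonist activity at transient receptor potential cation channel subfamily V member 1 (Homo sapiens), read by FLIPR (a higher number here means a weaker inhibitor, a lower number a stronger inhibitor), compound 1 `CC(C(=O)NCc1ccc(C(F)(F)F)nc1Nc1ccccc1)c1ccc(NS(C)(=O)=O)c(F)c1` gives 59.6 nM, the highest of the three numbers. Compound 2 `CC(C(=O)NCc1ccc(C(F)(F)F)nc1N1CC=CCC1)c1ccc(NS(C)(=O)=O)c(F)c1` gives 0.3 nM and compound 3 `CC(C(=O)NCc1ccc(C(F)(F)F)nc1N1CCC(C)(C)CC1)c1ccc(NS(C)(=O)=O)c(F)c1` gives 0.3 nM. Both steps away from compound 1 are large: a 200-fold lower number from compound 1 to compound 2 (2.30 log units; beyond the scatter) and a 200-fold lower number from compound 1 to compound 3 (2.30 log units; beyond the scatter), while no change at the digits printed from compound 2 to compound 3 (within the scatter), so two different saturated rings in this position gave the same result. Compound 4 `COC1CCN(c2nc(C(F)(F)F)ccc2CNC(=O)C(C)c2ccc(NS(C)(=O)=O)c(F)c2)CC1` carries 4-methoxypiperidin-1-yl in place of anilino on an aromatic carbon, a third saturated ring of the same kind. A large step of the same direction is therefore expected, a 150-fold lower number from compound 1 to compound 4 (2.17 log units; beyond the scatter). Compound 4 is expected to give about 0.4 nM, with a likely range from 0.15 nM to 1.2 nM.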

Compound 4, inhibition constant: 2.4 nM
The estimate for compound 4 lay 6.0-fold (0.78 log units) below the measured number; the measured number lies above the stated range.
By their numbers in this assay, from the lowest: compounds 2 and 3 (each within the scatter of the next); then compound 4; then compound 1.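

A non-aromatic ring on this aromatic carbon still far outperforms the anilino in this assay, with a 25-fold lower number from compound 1 to compound 4 (1.40 log units; beyond the scatter), but the ring's substituent also matters: an 8.0-fold higher number from compound 3 to compound 4 (0.90 log units; beyond the scatter) and an 8.0-fold higher number from compound 2 to compound 4 (0.90 log units; beyond the scatter). The matching numbers of compound 2 and compound 3 alone gave no sign of this difference. Nothing measured here explains the gap.

Going by these compounds, whether the oxygen or the whole methoxy group goes with the higher number remains open. So does how a 4-hydroxypiperidin-1-yl or a morpholine ring would compare at this position.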